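Bromo for Pentyl: What to Expect of Compound 3

A few compounds are considered here, and "the series" means these few. Any claim that something is new, unique, unknown or untested is made for them only; others in the source may bear on it.

Measured so far:
Compound 1, `CCCCCc1ccc(NC(=O)N[C@H](C)c2ccccc2)cc1`, gives 100% in an ADME assay on the whole organism with Oryza sativa as the target, tested at 0.1 uM; on this read-out higher numbers stand for a weaker effect at the one concentration tested and lower numbers for a stronger effect.
Compound 2, `CCCCCc1ccc(NC(=O)N[C@@H](C)c2ccccc2)cc1`, gives 98% in this assay.

Compound 1 stands highest of the two numbers, and compound 2 is its nearest neighbour: a number 2 percentage points lower from compound 1 to compound 2 (within the scatter). That step rests on (the fact that compounds 1 and 2 differ only in the configuration as drawn), so the two compounds are the same set of atoms drawn in mirror configurations, and the numbers do not separate them.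

Compound 3, `C[C@@H](NC(=O)Nc1ccc(Br)cc1)c1ccccc1`, has not yet been measured. Compared with compound 1 the change is bromo in place of pentyl on an aromatic carbon, on an aromatic carbon of a six-membered aromatic ring of carbon only. For the measured compounds named here, no measured step swaps one group for another on this ring; the only step available, a number 2 percentage points lower from compound 1 to compound 2 (within the scatter), concerns configuration alone and lies within the scatter. There is thus no measured basis for a step in either direction, and the expected step is a number 5 percentage points lower from compound 1 to compound 3 (within the scatter). As far as these compounds go, compound 3 is therefore estimated at 95% in this assay, with a range from 70% to 100%, the width reflecting that the change itself is untested.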

Compound 3, a percentage reported as activity, at one concentration (the size of the read-out at that concentration, not a potency): 100%
The estimate for compound 3 lay 5 percentage points below the measured number, and the stated range covers the measured number.
By their numbers in this assay, from the lowest: compounds 2, 1 and 3 (each within the scatter of the next).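

In this assay, setting bromo in place of pentyl on an aromatic carbon of the ring, para to a large group, gives no change at the digits printed from compound 1 to compound 3 (within the scatter). For the compounds shown here, compounds 1 and 2 spoke only to configuration, so this is the first measured change of group at this position. It shows that the pentyl chain of 5 heavy atoms can give way to a single bromine with no difference that this read-out can separate, which means the full length of the chain is not needed to give a number of this size. Going by these compounds alone, nothing measured so far gives a reason for this result, so it stands as an observation only.

As far as these compounds go, what remains open is whether this position tolerates any group at all in this assay or only these two, since a carboxylic acid, an amine or a much longer chain at the same place could still move the number beyond the scatter. The compounds shown also leave open whether the bromo compound drawn in the opposite configuration would read the same, and how any of these compounds would behave at a concentration other than the single one tested.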